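Replacing acetoxymethyl with 1-hydroxypropyl: what to expect

This account rests on a few compounds, and the source may have more. Where it says the series, first, only, none or still open, it means among the compounds named here.

Compound 1 `CC(C)=CC[C@@H](OC(=O)c1ccco1)C1=CC(=O)c2c(O)ccc(O)c2C1=O`: 80300 nM
Compound 2 `COC(C)CO[C@H](CC=C(C)C)C1=CC(=O)c2c(O)ccc(O)c2C1=O`: 53400 nM
Compound 3 `CC(=O)OCCO[C@H](CC=C(C)C)C1=CC(=O)c2c(O)ccc(O)c2C1=O`: 41500 nM

These three compounds were measured in a functional assay on HeLa cells (Homo sapiens) for cytotoxicity, read by MTT assay (on this read-out lower numbers stand for stronger inhibition and higher numbers for weaker inhibition), and their values lie close together. Compound 3 has no clear place of its own among them, since it cannot be separated from either of the others. Compound 4 `CCC(O)CO[C@H](CC=C(C)C)C1=CC(=O)c2c(O)ccc(O)c2C1=O` differs from compound 3 by having 1-hydroxypropyl in place of acetoxymethyl on a saturated chain carbon bound to an oxygen on a saturated carbon.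

Larger changes to the same side chain gave a 1.5-fold lower number from compound 1 to compound 2 (0.18 log units; within the scatter) and a 1.9-fold lower number from compound 1 to compound 3 (0.29 log units; within the scatter). Among the measured compounds shown here, the closest precedent, at the very place of the new change, gave a 1.3-fold lower number from compound 2 to compound 3 (0.11 log units; within the scatter). With steps this small, no step beyond the scatter is expected in this assay. For the measured compounds named here, no measured compound carries 1-hydroxypropyl, however, so the range stays wide. The expected change is a 1.2-fold higher number from compound 3 to compound 4 (0.06 log units; within the scatter). For compound 4 the estimated value is 48000 nM, with an expected range from 24000 nM to 95000 nM.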

Compound 4, half-maximal inhibitory concentration: 28700 nM
Compound 4: the middle estimate sits 1.7-fold (0.22 log units) above what was measured; measured number inside the range.
By their numbers in this assay, from the lowest: compounds 4, 3, 2 and 1 (each within the scatter of the next, the first and the last beyond it).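

In this assay, 1-hydroxypropyl in place of acetoxymethyl gives a 1.4-fold lower number from compound 3 to compound 4 (0.16 log units; within the scatter) and 1-hydroxypropyl in place of 1-methoxyethyl gives a 1.9-fold lower number from compound 2 to compound 4 (0.27 log units; within the scatter) on this saturated chain carbon, so a side chain with a hydrogen-bond donor stays within the scatter of both neighbours. Among the compounds shown here, only the larger change, 2-hydroxybutyl in place of (furan-2-yl)carbonyl on an oxygen on a saturated carbon, gives a 2.8-fold lower number from compound 1 to compound 4 (0.45 log units; beyond the scatter) and so, unlike the earlier steps, clears the scatter, though only modestly. No measured evidence is available to explain these numbers.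

The compounds shown do not separate the contribution of the hydroxyl from that of the carbon chain carrying it. On these data alone, whether an amine, a carboxylic acid or a longer chain at this place would move the number clearly beyond the scatter also stays open.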